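Replacing the Basic Amide with an Aryl Ester

The compounds below may be only part of what the source reports. "The series", "measured", "known", "first", "only" and "open" are said of these compounds alone.

Compound 2 `CCN(CC)CCNC(=O)c1ccc(C(CC)(CC)c2ccc(OCC(O)C(C)(C)C)c(C)c2)n1CC` is measured in an assay on HL-60 cells for agonist activity at vitamin D3 receptor (Homo sapiens), read by microscopy, with a stated time of 96 h (on this read-out lower numbers stand for an effect already at smaller amounts and higher numbers for an effect only at larger amounts of compound), at 110 nM. Of the two numbers recorded it is the higher one, yet its nearest neighbour, compound 1 `CCN(CC)CCNC(=O)c1ccc(C(CC)(CC)c2ccc(OCC(=O)C(C)(C)C)c(C)c2)n1CC`, gives 91 nM, and the gap is a 1.2-fold higher number from compound 1 to compound 2 (0.08 log units; within the scatter). Compound 3 `CCn1c(C(=O)Nc2cccc(C(F)(F)F)c2)ccc1C(CC)(CC)c1ccc(OCC(=O)C(C)(C)C)c(C)c1` reaches only a limit of the assay, > 50000 nM, and so carries no number. Compound 4 `CCOC(=O)c1ccc(OC(=O)c2ccc(C(CC)(CC)c3ccc(OCC(O)C(C)(C)C)c(C)c3)n2CC)cc1` has not been measured yet; it differs from compound 2 in one place: 4-(ethoxycarbonyl)phenoxy in place of (2-(diethylamino)ethyl)amino on a carbonyl carbon. The measured step that bears on this change is an at least 540-fold higher number from compound 1 to compound 3 (2.73 log units; beyond the scatter), in which the same 2-(diethylamino)ethyl group on the amide-type nitrogen gave way to an aromatic group. That step ends at the limit (the limit of > 50000 nM in this assay, at which 1 of the 3 values shown sits). Compound 4 likewise gives up the (2-(diethylamino)ethyl)amino group, here in favour of 4-(ethoxycarbonyl)phenoxy on the carbonyl carbon, so a large rise in the number, possibly onto that limit, is expected. For compound 4 the estimate is 20000 nM, between 2000 nM and 60000 nM. This amounts to an expected 180-fold higher number from compound 2 to compound 4 (2.26 log units; beyond the scatter).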

Compound 4, half-maximal effective concentration: > 50000 nM
Compound 4: only a limit was reported; the forecaster's own chance of this, stated with the estimate: 55%; at least 2.5-fold (0.39 log units) between middle value and limit.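

In this assay, the change gives an at least 450-fold higher number from compound 2 to compound 4 (2.65 log units; beyond the scatter), so the large loss seen earlier on the amide-type nitrogen also appears with the 1-hydroxy-2,2-dimethylpropyl group in the side chain and with an ester oxygen in place of the amide nitrogen on the carbonyl carbon. Compound 4 gives > 50000 nM, which is a limit of the assay and not a number. Both replacements of the 2-(diethylamino)ethyl group shown, one an aromatic amide and the other an aromatic ester, end at the same limit: the limit of > 50000 nM in this assay, at which 2 of the 4 values shown sit.

In compound 3 and compound 4, the diethylamino group leaves and an aromatic ring enters together, so the two changes cannot be separated. As far as these compounds go, it remains open whether a 2-(dimethylamino)ethyl amide, a longer aminoalkyl chain or a carboxylic acid on the carbonyl carbon would stay near compound 2 or also reach the limit.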